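Replacing 4-bromophenyl with 3,4-dichlorophenyl in compound 4

The source may report more compounds than this note shows. Statements on the series, on what has been measured and on what is new or still open speak of the compounds shown alone.

Compound 1 `CC(C)(C)c1ccc(CNC(=O)C2(c3ccc(NS(C)(=O)=O)cc3)CC2)cc1`: in a functional assay on CHO cells for antagonist activity at transient receptor potential cation channel subfamily V member 1 (Rattus norvegicus) (on this read-out lower numbers stand for stronger inhibition and higher numbers for weaker inhibition), compound 1 gives 1770 nM.
Compound 2 `CC(C(=O)NCc1ccc(Cl)cc1)c1ccc(NS(C)(=O)=O)c(F)c1`: in this assay compound 2 gives 367 nM.
Compound 3 `CC(C(=O)NCc1ccc(Br)cc1)c1ccc(NS(C)(=O)=O)c(F)c1`: in this assay compound 3 gives 250 nM.

Compound 3 has the lowest of the three numbers. Compound 2 lies closest to it, and the step of a 1.5-fold lower number from compound 2 to compound 3 (0.17 log units; within the scatter) is within the scatter, so the two cannot be ordered. Compound 1 shows the highest number of the three, clearly apart from compound 3.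

Compound 4 `CC(C(=O)NCc1ccc(Cl)c(Cl)c1)c1ccc(NS(C)(=O)=O)c(F)c1` differs from compound 3 in one place: 3,4-dichlorophenyl in place of 4-bromophenyl on a saturated chain carbon bound to an amide-type nitrogen. Among the measured compounds shown here, the only measured step that touches this position is a 1.5-fold lower number from compound 2 to compound 3 (0.17 log units; within the scatter), a swap of one halogen for another on the same aromatic carbon, and it stayed within the scatter. For the measured compounds named here, no measured pair shows what a second chlorine on that ring does, so that part of the change is untested. The account therefore expects compound 4 to move only by about a 1.3-fold lower number from compound 3 to compound 4 (0.10 log units; within the scatter), which would be no step beyond the scatter. Compound 4 is estimated at 200 nM, with a range from 80 nM to 500 nM.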

Compound 4, inhibition constant: 115 nM
Beside the measured number, compound 4's estimate is 1.7-fold (0.24 log units) above it; low and high end bracket the measured number.
By their numbers in this assay, from the lowest: compound 4; then compounds 3 and 2 (each within the scatter of the next); then compound 1.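

In this assay, among the compounds shown here, the ring on the saturated chain carbon bound to an amide-type nitrogen proves sensitive to its substitution: a 2.2-fold lower number from compound 3 to compound 4 (0.34 log units; beyond the scatter), whereas the only earlier step here, a swap of one halogen for another, stayed within the scatter. The added chlorine alone accounts for the other new step, a 3.2-fold lower number from compound 2 to compound 4 (0.50 log units; beyond the scatter), so in this pair a second halogen on the ring goes with a lower number, although both steps are modest. Nothing measured here says why the number falls.

The compounds shown leave open whether the lower number needs both chlorines, which a 3-chlorophenyl group would test, and whether it extends to a 3,4-dibromophenyl group. They also leave open whether the 3,4-dichlorophenyl group would have the same effect on the core of compound 1.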